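The source may report more compounds than this note shows. Statements on the series, on what has been measured and on what is new or still open speak of the compounds shown alone.

Of the compounds shown here, three built on one shared core have been measured in a functional assay on CHO cells for agonist activity at Alpha-1B adrenergic receptor (Homo sapiens), read by FLIPR and calcium flux; a lower number here means that less compound is needed, a higher number that more compound is needed for the effect. Compound 1 `CCCS(=O)(=O)Nc1cccc2c1CCC2c1ncc[nH]1` carries a (propylsulfonyl)amino group on an aromatic carbon of that core. In this assay compound 1 gives > 10000 nM, which is a limit of the assay and not a number. Compound 2 `c1cc(-c2ccn[nH]2)c2c(c1)C(c1ncc[nH]1)CC2` carries a 1H-pyrazol-5-yl group at the same place, and in this assay compound 2 gives 600 nM. Compound 3 `c1cncc(-c2cccc3c2CCC3c2ncc[nH]2)c1` carries a pyridin-3-yl group there. In this assay compound 3 gives > 10000 nM, again a limit of the assay rather than a number. Compound 3 thus sits at the limit of > 10000 nM in this assay, at which 2 of the 3 values shown sit, the weaker end of what has been seen so far.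

Compound 4 `CNC(=O)c1cccc2c1CCC2c1ncc[nH]1` differs from compound 3 in one place: methylcarbamoyl in place of pyridin-3-yl on an aromatic carbon. For the measured compounds named here, two measured steps bear on this exchange. The step of an at least 16-fold higher number from compound 2 to compound 3 (1.22 log units; beyond the scatter) is large and shows that the group at this position can move the number far. The step that the two limits leave unreadable from compound 1 to compound 3 cannot be read, since a limit stands on each side. Methylcarbamoyl, like the (propylsulfonyl)amino group of compound 1, has no ring, and compound 1 reached only its limit. The step that the limit leaves unreadable from compound 3 to compound 4 is therefore expected to be none beyond the scatter. Compound 4 is estimated at 12000 nM, in a range from 3000 nM to 40000 nM.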

Compound 4, half-maximal effective concentration: > 10000 nM
Compound 4: a limit, no number (the forecaster's own chance of this, stated with the estimate: 65%); the middle value is on the limit's open side.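

In this assay compound 4 gives > 10000 nM, which is a limit of the assay and not a number. The step of an at least 16-fold higher number from compound 2 to compound 4 (1.22 log units; beyond the scatter) is large, so a third, quite different group at this position, one with no ring and with the amide hydrogen of methylcarbamoyl, also falls far short of the 1H-pyrazol-5-yl group of compound 2. The steps among compounds 1, 3 and 4 cannot be read, since a limit stands on each side, so these three cannot be ranked against one another, and compound 2 remains the only compound here with a number: the limit of > 10000 nM in this assay, at which 3 of the 4 values shown sit.

What the compounds shown leave open is whether anything about 1H-pyrazol-5-yl beyond its being that particular group matters, since another five-membered aromatic ring such as imidazol-2-yl, a simple amine or a carboxylic acid on the same aromatic carbon would each help to tell. From the compounds shown here alone, how far the true values of compounds 1, 3 and 4 lie past their limits also stays unknown, and an assay run at higher concentrations would be needed to separate them.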